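The compounds below may be only part of what the source reports. "The series", "measured", "known", "first", "only" and "open" are said of these compounds alone.

Measured so far:
- compound 1, `Nc1scc(CN2CCN(c3cccnc3)CC2)c1C(=O)c1ccc(Cl)cc1`: -2.7%
- compound 2, `Nc1scc(CN2CCN(c3ccccc3F)CC2)c1C(=O)c1ccc(Cl)cc1`: -9.2%
- compound 3, `Nc1scc(CN2CCN(c3ccc(F)cc3F)CC2)c1C(=O)c1ccc(Cl)cc1`: -66%

In a functional assay on CHO cells with adenosine receptor A1 (Homo sapiens) as the target, read by cAMP accumulation and immunoassay, with a stated time of 6 min, tested at 1 uM (on this read-out higher numbers stand for a weaker effect at the one concentration tested and lower numbers for a stronger effect), compound 3 gives the lowest of the three numbers; compound 2 lies a number 56.8 percentage points lower from compound 2 to compound 3 (beyond the scatter), and compound 1 lies a number 63.3 percentage points lower from compound 1 to compound 3 (beyond the scatter), both beyond the scatter. Compound 4, `Nc1scc(CN2CCN(c3cccc(Cl)c3)CC2)c1C(=O)c1ccc(Cl)cc1`, differs from compound 3 by 3-chlorophenyl in place of 2,4-difluorophenyl on an amine nitrogen in a ring.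

Within the data shown here, the steps that bear on this change are those that alter the aryl on the ring amine nitrogen. The step of a number 6.5 percentage points lower from compound 1 to compound 2 (within the scatter) is within the scatter, whereas a number 56.8 percentage points lower from compound 2 to compound 3 (beyond the scatter) is large: a single fluoro added on an aromatic carbon took the number far down. Compound 4 removes both fluorines and carries a chloro instead, so the large downward step is not expected to be kept in full; a return part of the way toward compounds 1 and 2 is expected, with wide uncertainty since no chloro-substituted aryl has been measured here. The expected step is a number 36 percentage points higher from compound 3 to compound 4 (beyond the scatter), so compound 4 is estimated at -30%, within -70% to 5%.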

Compound 4, a percentage reported as activity, at one concentration (the size of the read-out at that concentration, not a potency): -59%
The estimate for compound 4 lay 29 percentage points above the measured number, within the range that was stated.
By their numbers in this assay, from the lowest: compounds 3 and 4 (each within the scatter of the next); then compounds 2 and 1 (each within the scatter of the next).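

In this assay, the aryl on the ring amine nitrogen tolerates an exchange of 3-chlorophenyl for 2,4-difluorophenyl with no readable shift, a number 7 percentage points higher from compound 3 to compound 4 (within the scatter), so the low number at this position does not belong to the difluorinated ring alone. The same replacement gives large steps against the other two aryl groups, a number 49.8 percentage points lower from compound 2 to compound 4 (beyond the scatter) and a number 56.3 percentage points lower from compound 1 to compound 4 (beyond the scatter), so compounds 1 and 2 remain the two that stay apart, and the outcome here turns on which aryl is present rather than on fluorine. Nothing at hand explains why these two different aryl groups land together.

On these data alone, it remains open where an unsubstituted phenyl, a methoxyphenyl or a trifluoromethylphenyl would fall at this position. A single-concentration read-out also leaves open whether compounds 3 and 4 match in potency.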